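Fluorine on the cyanophenyl ring across two amide cores

This account rests on a few compounds, and the source may have more. Where it says the series, first, only, none or still open, it means among the compounds named here.

Measured so far in a functional assay on CWR22R cells (Homo sapiens) for antiproliferative activity, read by propidium iodide staining, with a stated time of 96 h; on this read-out higher numbers stand for weaker inhibition and lower numbers for stronger inhibition:
compound 1 `CC(O)(COc1ccc(C#N)cc1)C(=O)Nc1ccc(S(F)(F)(F)(F)F)cc1` gave 26100 nM
compound 2 `CC(O)(COc1ccc(C#N)c(F)c1)C(=O)Nc1ccc(S(F)(F)(F)(F)F)cc1` gave 24300 nM
compound 3 `CC(O)(COc1ccc(C#N)cc1)C(=O)Nc1cccc(S(F)(F)(F)(F)F)c1` gave 32500 nM

Compound 2 differs from compound 1 by fluoro in place of hydrogen on an aromatic carbon, and this change gave a 1.1-fold lower number from compound 1 to compound 2 (0.03 log units; within the scatter). Compound 3 has the same atoms as compound 1 joined differently; the difference between the two cores is not broken down here, and the two values lie within the scatter of each other. Compound 4 `CC(O)(COc1ccc(C#N)c(F)c1)C(=O)Nc1cccc(S(F)(F)(F)(F)F)c1` has not yet been measured in this assay. It differs from compound 3 by fluoro in place of hydrogen on an aromatic carbon, the same change, made at the same kind of place, as that between compound 1 and compound 2. Because the earlier step gave a 1.1-fold lower number from compound 1 to compound 2 (0.03 log units; within the scatter), the step from compound 3 to compound 4 is expected to be a 1.1-fold lower number from compound 3 to compound 4 (0.03 log units; within the scatter). Compound 4 is therefore estimated at 30000 nM, likely between 15000 nM and 60000 nM.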

Compound 4, half-maximal inhibitory concentration: 63400 nM
Compound 4: middle estimate off by 2.1-fold (0.32 log units), on the low side, outside the stated range (above it).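

In this assay the fluoro in place of hydrogen, ortho to a cyano group, gave a 2.0-fold higher number from compound 3 to compound 4 (0.29 log units; within the scatter) and so establishes no effect of this change on this core. Neither step shows a real shift on its own, so the series does not show that the change acts differently on the two cores, nor does it fix a size that could be carried from one core to another. The apparent opposite direction of the two steps cannot be read as a difference between the cores: the same change on two cores in this assay, a 1.1-fold lower number (0.03 log units; within the scatter) from compound 1 to compound 2 and a 2.0-fold higher number (0.29 log units; within the scatter) from compound 3 to compound 4, 2.1-fold (0.32 log units) apart, within the scatter of two such steps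

Going by these compounds, it remains open whether a chlorine or a methoxy group in place of this fluoro would give a step beyond the scatter. The same holds for a carboxylic acid in place of the cyano group.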